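The source may report more compounds than this note shows. Statements on the series, on what has been measured and on what is new or still open speak of the compounds shown alone.

Measured so far:
Compound 1 `CC(C)C(NC(=O)c1ccc(C#Cc2ccccc2)cc1)C(=O)NO` gives 7000 nM in a physicochemical assay for solubility; a higher number here means a more soluble compound, a lower number a less soluble compound.
Compound 2 `CSC[C@H](NC(=O)c1ccc(C#Cc2ccccc2)cc1)C(=O)NO` gives 2000 nM.

For the measured compounds named here, compound 2 holds the lower of the two numbers; its only neighbour is compound 1, reached by a 3.5-fold lower number from compound 1 to compound 2 (0.54 log units; beyond the scatter), a modest but real drop. The unmeasured compound 3 `CC(NC(=O)c1ccc(C#Cc2ccccc2)cc1)C(=O)NO` differs from compound 2 by a group of 6 heavy atoms (3 carbon, 1 nitrogen, 2 oxygen; no ring) in place of a group of 8 heavy atoms (4 carbon, 1 nitrogen, 2 oxygen, 1 sulfur; no ring), on an amide-type nitrogen.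

Going by the values given here, only one measured step exists, that from compound 1 to compound 2, and it exchanged one group for another of the same size on the same amide-type nitrogen. Among the compounds with values here, the present step instead removes two heavy atoms, the sulfur among them, and no measured pair tests that. The measured step bears on it only in showing that changes at this position move the number by a modest amount in either direction. Compound 3 is therefore expected to shift by a 2.0-fold higher number from compound 2 to compound 3 (0.30 log units; within the scatter), a rise of about the size already seen, landing near the number of compound 1. The estimate for compound 3 is 4000 nM, with a range from 1500 nM to 10000 nM, the width reflecting the lack of a direct precedent.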

Compound 3, solubility: 29000 nM
Compound 3: the middle estimate sits 7.3-fold (0.86 log units) below what was measured; measured number above the stated range.
By their numbers in this assay, from the lowest: compound 2; then compound 1; then compound 3.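

In this assay, the group on the amide-type nitrogen can move the number much further than the first pair indicated: a 15-fold higher number from compound 2 to compound 3 (1.16 log units; beyond the scatter), a large step set against the modest 3.5-fold lower number from compound 1 to compound 2 (0.54 log units; beyond the scatter). Compound 3 also stands clear of the isopropyl compound, with methyl in place of isopropyl on a saturated chain carbon giving a 4.1-fold higher number from compound 1 to compound 3 (0.62 log units; beyond the scatter), so among these three compounds the methyl compound holds the highest number, with both of its steps beyond the scatter. Heavy-atom count alone does not order the series, since the groups of compound 1 and compound 2 have equal counts yet their numbers differ, and nothing at hand accounts for any of these steps.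

Still open, from the compounds shown here alone, is whether the number keeps rising with a plain hydrogen in place of the methyl, and where an ethyl group or a longer chain would fall relative to compound 3. Also open, going by these compounds, is how an amine or a carboxylic acid on this chain carbon would compare with the methyl of compound 3.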